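A few compounds are considered here, and "the series" means these few. Any claim that something is new, unique, unknown or untested is made for them only; others in the source may bear on it.

Measured so far in an assay on isolated protein for inhibition of thiosulfate sulfurtransferase (Homo sapiens); a lower number here means a stronger inhibitor, a higher number a weaker inhibitor:
Compound 1 `O=S(=O)(Nc1ccc(-c2nc3cc(NS(=O)(=O)c4ccccc4)ccc3o2)cc1)c1ccccc1` gives > 100000 nM, which is a limit of the assay.
Compound 2 `COc1ccc(S(=O)(=O)Nc2ccc3oc(-c4ccc(NC(=O)c5ccc(Cl)s5)cc4)nc3c2)cc1` gives > 100000 nM, again a limit.
Compound 3 `O=S(=O)(Nc1ccc(-c2nc3cc(NS(=O)(=O)c4cccc5ccccc45)ccc3o2)cc1)c1cccc2ccccc12` gives > 100000 nM, also a limit.

Compound 2 therefore stands at the same point as every other measured compound: none of the three gives a number, and the whole set sits at the limit of > 100000 nM in this assay, at which 3 of the 3 values shown sit. Among the measured compounds shown here, no step between measured compounds can be read from the series, so nothing is known about how far any change moves this assay.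

Compound 4 `COc1ccc(S(=O)(=O)Nc2ccc3oc(-c4ccc(NS(=O)(=O)c5cc(F)ccc5OC)cc4)nc3c2)cc1` differs from compound 2 in one place: a group of 12 heavy atoms (7 carbon, 3 oxygen, 1 fluorine, 1 sulfur; one six-membered aromatic ring of carbon only) in place of a group of 8 heavy atoms (5 carbon, 1 oxygen, 1 sulfur, 1 chlorine; one five-membered aromatic ring with 1 hetero atom), on a nitrogen on an aromatic ring. With that, compound 4 carries two sulfonamide nitrogens on the shared core, as compound 1 and compound 3 do, and those two both stopped at the limit.

Expectation: with three of three values at the limit and no sign from any measured pair that this assay responds to changes of this sort, the step from compound 2 to compound 4 is expected to lie within the scatter, a step that the limit leaves unreadable from compound 2 to compound 4, with the outcome most likely again a limit rather than a number. Compound 4 is estimated at 150000 nM, in the range 30000 nM to 1000000 nM.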

Compound 4, half-maximal inhibitory concentration: > 100000 nM
Compound 4 ended at the assay's limit (the forecaster's own chance of this, stated with the estimate: 85%); the middle value does not contradict the limit.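

Among the compounds shown here, compound 2 and compound 4 both end at a limit in this assay, so no step between them can be read. The compounds shown leave open whether any change on the shared core yields a number rather than a limit in this assay: the limit of > 100000 nM in this assay, at which 4 of the 4 values shown sit.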